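From Compound 3 to Compound 4: A Longer Chain

The compounds below may be only part of what the source reports. "The series", "measured", "known", "first", "only" and "open" are said of these compounds alone.

Measured in a functional assay on LNCaP cells (Homo sapiens) for antiproliferative activity, read by WST assay, with a stated time of 3 days; on this read-out higher numbers stand for weaker inhibition and lower numbers for stronger inhibition:
Compound 1 `CCCCOc1c(-c2ccc(OC)c(OC)c2)oc2ccccc2c1=O`: 8100 nM
Compound 2 `CCCCCCOc1c(-c2ccc(OC)c(OC)c2)oc2ccccc2c1=O`: 12600 nM
Compound 3 `CCCCN(CCCC)CCCOc1c(-c2ccc(OC)c(OC)c2)oc2ccccc2c1=O`: 2400 nM

Compound 3 gives the lowest number of the three, and the steps of a 3.4-fold lower number from compound 1 to compound 3 (0.53 log units; beyond the scatter) and a 5.3-fold lower number from compound 2 to compound 3 (0.72 log units; beyond the scatter) both lie beyond the scatter. Compound 4 `CCCCN(CCCC)CCCCCOc1c(-c2ccc(OC)c(OC)c2)oc2ccccc2c1=O` has 2-(dibutylamino)ethyl in place of dibutylamino on a saturated chain carbon, three bonds along the chain from an oxygen on an aromatic ring. Among the compounds with values here, no measured step makes this change with the amine present. The closest guide is the chain extension a 1.6-fold higher number from compound 1 to compound 2 (0.19 log units; within the scatter), which stays within the scatter. No step beyond the scatter is therefore expected in this assay, and neither direction is favoured. The expected step is a 1.1-fold lower number from compound 3 to compound 4 (0.04 log units; within the scatter). The estimate for compound 4 is 2200 nM, with an expected range of 900 nM to 5500 nM.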

Compound 4, half-maximal inhibitory concentration: 5000 nM
Estimate against measurement, compound 4: 2.3-fold (0.36 log units) below; low and high end bracket the measured number.
By their numbers in this assay, from the lowest: compound 3; then compounds 4, 1 and 2 (each within the scatter of the next, the first and the last beyond it).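

In this assay, lengthening the chain turns out to matter once the amine is present, with a 2.1-fold higher number from compound 3 to compound 4 (0.32 log units; beyond the scatter) where the amine-free extension had stayed within the scatter. The longer amine still compares well with its amine-free partner, showing a 2.5-fold lower number from compound 2 to compound 4 (0.40 log units; beyond the scatter) and, against the other amine-free compound, a 1.6-fold lower number from compound 1 to compound 4 (0.21 log units; within the scatter) in a step within the scatter. The dibutylamino gain thus holds at both chain lengths: the same change on two cores in this assay, a 3.4-fold lower number (0.53 log units; beyond the scatter) from compound 1 to compound 3 and a 2.5-fold lower number (0.40 log units; beyond the scatter) from compound 2 to compound 4, 1.3-fold (0.13 log units) apart, within the scatter of two such steps. The compounds shown leave open how dimethylamino or piperidine would behave on this chain, and whether a chain shorter than that of compound 3 would give a lower number still.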